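Swapping the aryl group on a sulfonyl in mGlu5 binders

The compounds below may be only part of what the source reports. "The series", "measured", "known", "first", "only" and "open" are said of these compounds alone.

Measured so far:
compound 1 `Cc1cc(C)cc(S(=O)(=O)c2cnc3ccc(F)cc3c2N2CCC(C)CC2)c1` with 83%
compound 2 `Cc1ccc2ncc(S(=O)(=O)c3ccc(Cl)cc3)c(N3CCC(C)CC3)c2c1` with 79%

Both measured compounds were tested in an assay on isolated protein for displacement of a labelled ligand from metabotropic glutamate receptor 5 (Homo sapiens), with a stated time of 60 min, tested at 1 uM; on this read-out higher numbers stand for more inhibition at the one concentration tested (going by the name of the read-out) and lower numbers for less inhibition. In this assay compound 1 gives 83%, and compound 2 gives 79%. The two numbers lie within the usual scatter of each other, so neither compound can be called the stronger; compound 1 simply shows the larger of two numbers that are effectively the same. The two share a core and differ in more than one place, so their pair tells nothing about any single change.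

Compound 3 `COc1cccc(S(=O)(=O)c2cnc3ccc(F)cc3c2N2CCC(C)CC2)c1` is derived from compound 1 by one change on the sulfonyl sulfur: 3-methoxyphenyl in place of 3,5-dimethylphenyl on a sulfonyl sulfur. For the measured compounds named here, no measured pair shows the effect of this change, so the expectation rests only on the two numbers above, which both show strong displacement for an aryl sulfone on this core. For compound 3 the step of a number 8 percentage points lower from compound 1 to compound 3 (within the scatter) is expected to be small, and a modest fall not beyond the scatter is the most likely outcome. Compound 3 is estimated at 75% in this assay, within a range from 55% to 90%.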

Compound 3, a percentage reported as inhibition, at one concentration (the size of the read-out at that concentration, not a potency): 90%
Compound 3: middle estimate off by 15 percentage points, on the low side; low and high end bracket the measured number.
By their numbers in this assay, from the lowest: compounds 2, 1 and 3 (each within the scatter of the next, the first and the last beyond it).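

In this assay, for the compounds shown here, the swap on the sulfonyl sulfur gives a number 7 percentage points higher from compound 1 to compound 3 (within the scatter) and so offers the first comparison in which only this group differs; 3-methoxyphenyl and 3,5-dimethylphenyl cannot be told apart on this measure. The entering group has the same number of heavy atoms as the leaving group but brings an oxygen and a hydrogen-bond acceptor, and strong displacement at the one concentration tested is kept, so on the shared core this position accepts this particular change. Nothing measured here gives a reason for this outcome.

On these data alone, it remains open whether this position would accept a phenyl ring carrying an amine or a carboxylic acid, or a saturated group such as cyclohexyl in place of the aromatic ring. As far as these compounds go, each number also gives only the size of the read-out at a single concentration, so whether compound 1 and compound 3 would differ in potency across a range of concentrations is still unknown.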